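Urea-linked oxadiazole series: acetamido-bromophenyl variant

A few compounds are considered here, and "the series" means these few. Any claim that something is new, unique, unknown or untested is made for them only; others in the source may bear on it.

Compound 1 `CC(=O)Nc1ccc(S(=O)(=O)Nc2cccc(-c3nc(-c4ccc(NC(=O)c5cccnc5)cc4Cl)no3)c2)cc1Cl`: in a functional assay on MDA-MB-231 cells (Homo sapiens) for antiproliferative activity, read by MTT assay, with a stated time of 72 h (a lower number here means a stronger inhibitor, a higher number a weaker inhibitor), compound 1 reaches only the limit of > 10000 nM, which is a limit and not a number.
Compound 2 `COc1ccc(NC(=O)Nc2cccc(-c3nc(-c4ccc(NC(=O)c5cccnc5)cc4Cl)no3)c2)cc1C(F)(F)F`: compound 2 gives 1700 nM.
Compound 3 `CS(=O)(=O)Nc1ccc(NC(=O)Nc2cccc(-c3nc(-c4ccc(NC(=O)c5cccnc5)cc4Cl)no3)c2)cc1C(F)(F)F`: compound 3 gives 700 nM.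

Among the two numbers shown in this assay, compound 2 holds the highest; its nearest neighbour is compound 3, and the step of a 2.4-fold lower number from compound 2 to compound 3 (0.39 log units; beyond the scatter) is modest but beyond the scatter. Compound 1 contributes only a limit, (the limit of > 10000 nM in this assay, at which 1 of the 3 values shown sits), and so gives no number to compare.

Compound 4 `CC(=O)Nc1ccc(NC(=O)Nc2cccc(-c3nc(-c4ccc(NC(=O)c5cccnc5)cc4Cl)no3)c2)cc1Br` is not yet measured. It differs from compound 2 in one place: 4-acetamido-3-bromophenyl in place of 4-methoxy-3-(trifluoromethyl)phenyl on an amide-type nitrogen. Going by the values given here, the only measured step that bears on this change is a 2.4-fold lower number from compound 2 to compound 3 (0.39 log units; beyond the scatter), where an amide-type hydrogen-bond donor entered on the same ring in place of methoxy and the number fell moderately. Among the compounds with values here, compound 4 likewise carries a donor-bearing acetamido group, but with bromine in place of trifluoromethyl, for which no measured step exists in this assay. He therefore expects a small lowering of the number, of a size comparable to or smaller than that seen toward compound 3, though a step within the scatter would not surprise.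

For compound 4 in this assay the estimate is 1100 nM, with a range from 400 nM to 4000 nM, which corresponds to an expected step of a 1.5-fold lower number from compound 2 to compound 4 (0.19 log units; within the scatter).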

Compound 4, half-maximal inhibitory concentration: 1000 nM
Compound 4: middle estimate off by 1.1-fold (0.04 log units), on the high side, and the stated range covers the measured number.
By their numbers in this assay, from the lowest: compounds 3, 4 and 2 (each within the scatter of the next, the first and the last beyond it). At a limit, above all of these: compound 1.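

In this assay, replacing the whole 4-methoxy-3-(trifluoromethyl)phenyl on an amide-type nitrogen with 4-acetamido-3-bromophenyl gives a 1.7-fold lower number from compound 2 to compound 4 (0.23 log units; within the scatter), so at this position the trifluoromethyl and the methoxy can both be exchanged in one step without a change beyond the scatter. The earlier step on this ring replaced the methoxy alone and kept the trifluoromethyl, whereas this one shows that the number also holds when bromine stands in the trifluoromethyl's place and an acetamido group in the methoxy's, although the two exchanges cannot be told apart within this single step. The compounds shown offer nothing that accounts for the size of this step.

It remains open how the acetamido group and the bromine each contribute, since a compound carrying only one of these exchanges is not among those shown. Also open, from the compounds shown here alone, is whether a free amine or a carboxylic acid in place of the acetamido group, or a nitrile or a methyl group in place of the bromine, would leave the number in the same range.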